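The source may hold more compounds than are shown below. What is called first, only, known or untested is meant among the compounds shown, and "the series" means these compounds.

Measured compounds and values:

- compound 1, `Cc1cccc([C@@H]2C[C@H](O)Cc3ccccc3N2)c1`, 176000 nM
- compound 2, `O[C@@H]1Cc2ccccc2N[C@H](c2cccc(Cl)c2)C1`, 167000 nM
- compound 3, `Cc1ccc2c(c1)C[C@@H](O)C[C@@H](c1ccccc1Cl)N2`, 85200 nM

All three were read in an ADME assay on THP-1 cells (Homo sapiens) for cytotoxicity, read by MTT assay, with a stated time of 72 h; on this read-out higher numbers stand for lower toxicity in this test and lower numbers for higher toxicity in this test. Compound 1 gives 176000 nM and compound 2 gives 167000 nM; the change between them is chloro in place of methyl on an aromatic carbon and the step is a 1.1-fold lower number from compound 1 to compound 2 (0.02 log units; within the scatter). Compound 3 gives 85200 nM; its number is the lowest of the three, within the scatter of compound 2 and beyond the scatter of compound 1. The difference between the core of compound 1 and the core of compound 3 is not broken down here.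

Compound 4, `O[C@@H]1Cc2cc(Cl)ccc2N[C@H](c2ccccc2Cl)C1`, has not yet been measured in this assay. It differs from compound 3 by chloro in place of methyl on an aromatic carbon. This is the same kind of change as that from compound 1 to compound 2, but not the same: there the place was on a six-membered aromatic ring of carbon only, meta to a large group, whereas here the place is on a ring that is part of a fused or bridged system of two rings, meta to a fused ring and para to a fused ring.

In this assay the step from compound 3 to compound 4 is expected to be about a 1.1-fold lower number from compound 3 to compound 4 (0.04 log units; within the scatter), because a 1.1-fold lower number from compound 1 to compound 2 (0.02 log units; within the scatter) is the one shown example of this kind of change and lies within the scatter. The estimate for compound 4 is 78000 nM, expected to lie between 40000 nM and 160000 nM.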

Compound 4, half-maximal cytotoxic concentration: 75500 nM
Estimate against measurement, compound 4: 1.0-fold (0.01 log units) above; low and high end bracket the measured number.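

In this assay the new step is a 1.1-fold lower number from compound 3 to compound 4 (0.05 log units; within the scatter), and chloro in place of methyl on an aromatic carbon reads alike on the two cores: the same change on two cores in this assay, a 1.1-fold lower number (0.02 log units; within the scatter) from compound 1 to compound 2 and a 1.1-fold lower number (0.05 log units; within the scatter) from compound 3 to compound 4, 1.1-fold (0.03 log units) apart, within the scatter of two such steps. For these two pairs the change therefore carries from one core to the other with no step beyond the scatter, although the place differs, being meta to a large group in the earlier pair and, in the new pair, on a ring that is part of a fused or bridged system of two rings. For the compounds shown here, this shows only that the exchange left the number within the scatter in both cases; with just two pairs, it does not show that the same would hold on a further core or at another place, and it gives no reason why methyl and chloro read alike here.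

The compounds shown leave open what a group of another kind, such as an amine, a carboxylic acid or a longer chain, would do at these same places. Also open, from the compounds shown here alone, is whether the exchange of methyl for chloro stays this small in any read-out other than this assay.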